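A few compounds are considered here, and "the series" means these few. Any claim that something is new, unique, unknown or untested is made for them only; others in the source may bear on it.

Measured compounds, binding to an assay on isolated protein for displacement of a labelled ligand from D(4) dopamine receptor (Homo sapiens); on this read-out higher numbers stand for weaker inhibition and lower numbers for stronger inhibition:

compound 1, `O=C(NC1CCN(Cc2ccccc2Cl)CC1)c1cccc2ccccc12`: 329 nM
compound 2, `O=C(NC1CCN(Cc2cccc(Br)c2)CC1)c1cccc2ccccc12`: 66 nM
compound 3, `O=C(NC1CCN(Cc2ccc(C(F)(F)F)cc2)CC1)c1cccc2ccccc12`: 96 nM

Compound 3 stands second highest of the three numbers in this assay. Its nearest neighbour is compound 2, with a 1.5-fold higher number from compound 2 to compound 3 (0.16 log units; within the scatter) separating them, which lies within the scatter; its furthest is compound 1, with a 3.4-fold lower number from compound 1 to compound 3 (0.53 log units; beyond the scatter) lying beyond the scatter.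

The next compound, compound 4, `Cc1ccc(CN2CCC(NC(=O)c3cccc4ccccc34)CC2)cc1`, keeps the shared core and differs from compound 3 in one place: methyl in place of trifluoromethyl on an aromatic carbon. The new group sits on an aromatic carbon of the six-membered aromatic ring of carbon only, para to a large group.

Going by the values given here, no measured step exchanges one group for another at this same position, so none bears on it directly. The nearest evidence is the exchange of the whole substituted ring, in which a 1.5-fold higher number from compound 2 to compound 3 (0.16 log units; within the scatter) stayed within the scatter while a 5.0-fold lower number from compound 1 to compound 2 (0.70 log units; beyond the scatter) and a 3.4-fold lower number from compound 1 to compound 3 (0.53 log units; beyond the scatter) were modest. The change here is smaller than any of those, and no step beyond the scatter is expected in this assay.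

Compound 4 is therefore expected to give 110 nM, in the range 45 nM to 270 nM, which would mean a step of a 1.1-fold higher number from compound 3 to compound 4 (0.06 log units; within the scatter).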

Compound 4, inhibition constant: 69 nM
Compound 4: middle estimate off by 1.6-fold (0.20 log units), on the high side; the measured number falls inside the stated range.
By their numbers in this assay, from the lowest: compounds 2, 4 and 3 (each within the scatter of the next); then compound 1.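

At the position on an aromatic carbon para to a large group, the one direct exchange shown in this assay is methyl in place of trifluoromethyl, and it gives a 1.4-fold lower number from compound 3 to compound 4 (0.14 log units; within the scatter), so replacing four heavy atoms with one leaves the read-out within the scatter. The 4-methylphenyl group also reads level with the 3-bromophenyl group, at a 1.0-fold higher number from compound 2 to compound 4 (0.02 log units; within the scatter), whereas set against 2-chlorophenyl it gives a 4.8-fold lower number from compound 1 to compound 4 (0.68 log units; beyond the scatter), a modest step of the same kind already seen for the other two substituted rings. Nothing available here accounts for methyl and trifluoromethyl reading alike at this position.

Going by these compounds, it remains open whether this position accepts groups of other kinds just as readily: an amine, a carboxylic acid, a methoxy group or a longer chain such as propyl on the same aromatic carbon could still give a step beyond the scatter. Also open, on these data alone, is how the read-out responds to changes elsewhere in the shared core, as the carbonyl and the amide hydrogen stay the same in all four compounds.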